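Swapping cyano for bromo: what compound 4 may show

The source may report more compounds than this note shows. Statements on the series, on what has been measured and on what is new or still open speak of the compounds shown alone.

Compound 1 `O=S(=O)(/C=C/c1ccccc1)Cc1ccc(Nc2ncnc3ccccc23)cc1`: 5000 nM
Compound 2 `N#Cc1ccc(/C=C/S(=O)(=O)Cc2ccc(Nc3ncnc4ccccc34)cc2)cc1`: > 100000 nM
Compound 3 `O=S(=O)(/C=C/c1ccc(Cl)c(Cl)c1)Cc1ccc(Nc2ncnc3ccccc23)cc1`: 22000 nM

In a functional assay on SK-OV-3 cells (Homo sapiens) (on this read-out higher numbers stand for weaker inhibition of growth and lower numbers for stronger inhibition of growth), compound 2 has only a limit of the assay and not a number (> 100000 nM).

Compound 4 `O=S(=O)(/C=C/c1ccc(Br)cc1)Cc1ccc(Nc2ncnc3ccccc23)cc1` is still unmeasured. It differs from compound 2 by one swap, bromo in place of cyano on an aromatic carbon, para to a large group (bromo in place of cyano on an aromatic carbon).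

Within the data shown here, three measured steps bear on this swap. Adding cyano gave a large move (an at least 20-fold higher number from compound 1 to compound 2 (1.30 log units; beyond the scatter)). Changing phenyl to 3,4-dichlorophenyl gave only a modest one (a 4.4-fold higher number from compound 1 to compound 3 (0.64 log units; beyond the scatter)). The closest parallel removes the 4-cyanophenyl and is at least modest (an at least 4.5-fold lower number from compound 2 to compound 3 (0.65 log units; beyond the scatter)). Losing the cyano is therefore expected to bring the number down by a step of at least modest size, with compound 4 likely landing near compound 3 (22000 nM). The move expected in this assay is a drop (an at least 6.6-fold lower number from compound 2 to compound 4 (0.82 log units; beyond the scatter)). For compound 4 the estimate is 15000 nM (expected range 5000 nM to 50000 nM).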

Compound 4, concentration for 50% growth inhibition: 1000 nM
For compound 4 the middle estimate is 15-fold (1.18 log units) above the measured one; measured number below the stated range.
By their numbers in this assay, from the lowest: compound 4; then compound 1; then compound 3. At a limit, above all of these: compound 2.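

Among these compounds, until this result, both changes to the phenyl ring of compound 1 had raised the number in this assay, but bromo on this aromatic carbon, para to a large group, lowers it, giving a 5.0-fold lower number from compound 1 to compound 4 (0.70 log units; beyond the scatter). The choice of group here also matters greatly: bromo in place of cyano gives an at least 100-fold lower number from compound 2 to compound 4 (2.00 log units; beyond the scatter), and 4-bromophenyl in place of 3,4-dichlorophenyl gives a 22-fold lower number from compound 3 to compound 4 (1.34 log units; beyond the scatter). The first of these two steps rests on compound 2, which has only a limit of the assay and not a number: the limit of > 100000 nM in this assay, at which 1 of the 4 values shown sits.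

On these data alone, whether a single chloro, a fluoro, a methyl or an amine on this same carbon would also lower the number remains open. As far as these compounds go, it is equally open whether bromo on a different carbon of this ring would do the same.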